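The compounds below may be only part of what the source reports. "The series", "measured", "known", "first", "only" and "open" are said of these compounds alone.

In a functional assay on A549 cells (Homo sapiens) for antiproliferative activity, read by MTT assay, with a stated time of 48 h (a higher number here means a weaker inhibitor, a lower number a stronger inhibitor), compound 1 `COc1ccc(/C=C/C(=O)Nc2nnc(-c3ccc(C)cc3)s2)cc1` gives 0.66 ug/mL. Compound 2 `Cc1ccc(/C=C/C(=O)Nc2nnc(-c3ccc(C)cc3)s2)cc1`, at 1.08 ug/mL, cannot be told apart from it, while compound 3 `Cc1ccc(-c2nnc(NC(=O)/C=C/c3ccccc3)s2)cc1`, at 1.38 ug/mL, stands modestly apart, with a 2.1-fold higher number from compound 1 to compound 3 (0.32 log units; beyond the scatter). Compound 4 `COc1ccc(/C=C/C(=O)Nc2nnc(-c3ccc(OC)cc3)s2)cc1` differs from compound 1 by one exchange, 4-methylphenyl to 4-methoxyphenyl: methoxy in place of methyl on an aromatic carbon. Within the data shown here, no measured pair makes this change at this aromatic carbon. The closest evidence is the same two groups exchanged at a different aromatic carbon, where a 1.6-fold higher number from compound 1 to compound 2 (0.21 log units; within the scatter). Removing that methyl also gave little, with a 1.3-fold higher number from compound 2 to compound 3 (0.11 log units; within the scatter). No shift beyond the scatter is therefore expected, only an estimated 1.1-fold lower number from compound 1 to compound 4 (0.04 log units; within the scatter). Compound 4 is expected at 0.6 ug/mL, with an estimated range of 0.3 ug/mL to 1.2 ug/mL.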

Compound 4, half-maximal inhibitory concentration: 0.52 ug/mL
Estimate against measurement, compound 4: 1.2-fold (0.06 log units) above; low and high end bracket the measured number.
By their numbers in this assay, from the lowest: compounds 4, 1, 2 and 3 (each within the scatter of the next, the first and the last beyond it).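

Among these compounds, the exchange of 4-methylphenyl for 4-methoxyphenyl gives a 1.3-fold lower number from compound 1 to compound 4 (0.10 log units; within the scatter), which is the first direct reading of this change at this position in this assay. Here, methoxy, with its added oxygen and hydrogen-bond acceptor, cannot be told apart from methyl. Nothing measured here explains this result.

The compounds shown leave open whether this position would tolerate a very different group, such as an amine, a carboxylic acid or a longer chain. They also leave open what plain hydrogen would do at this position.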